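Exchanging the aromatic ring on the shared core

The source may report more compounds than this note shows. Statements on the series, on what has been measured and on what is new or still open speak of the compounds shown alone.

For the measured compounds named here, compound 2 `COc1cccc(/C=N/NC(=O)CSc2nnc(-c3ccncc3)o2)c1` is one of two compounds measured in a functional assay on MCF7 cells (Homo sapiens) for cytotoxicity, read by MTT assay, with a stated time of 48 h; on this read-out higher numbers stand for weaker inhibition and lower numbers for stronger inhibition. In this assay compound 2 gives 13800 nM, the lowest of the two numbers, and the nearest compound, compound 1 `O=C(CSc1nnc(-c2ccncc2)o1)N/N=C/c1ccc(Br)cc1`, gives 19100 nM in this assay. Going by the values given here, the only measured step, a 1.4-fold lower number from compound 1 to compound 2 (0.14 log units; within the scatter), sits within the scatter. Compound 3 `O=C(CSc1nnc(-c2ccncc2)o1)N/N=C/c1ccccc1O` has not yet been measured. It differs from compound 2 in one place: 2-hydroxyphenyl in place of 3-methoxyphenyl on a carbon with a double bond to nitrogen. Among the compounds with values here, the only measured step that bears on this change is a 1.4-fold lower number from compound 1 to compound 2 (0.14 log units; within the scatter), which also exchanged the aromatic ring on the same carbon and stayed within the scatter. On that basis no step beyond the scatter is expected in this assay for compound 3. The expected step from compound 2 to compound 3 is a 1.0-fold higher number from compound 2 to compound 3 (0.01 log units; within the scatter). Compound 3 is therefore estimated at 14000 nM, with a range from 5000 nM to 40000 nM.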

Compound 3, half-maximal inhibitory concentration: 4750 nM
Compound 3: middle estimate off by 2.9-fold (0.47 log units), on the high side; measured number outside the range, below it.
By their numbers in this assay, from the lowest: compound 3; then compounds 2 and 1 (each within the scatter of the next).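

Exchanging the aromatic ring on this carbon can move the number beyond the scatter in this assay, which the earlier exchange of 4-bromophenyl for 3-methoxyphenyl did not show. The 2-hydroxyphenyl group gives a 2.9-fold lower number from compound 2 to compound 3 (0.46 log units; beyond the scatter) and, measured against the bromine-bearing ring, a 4.0-fold lower number from compound 1 to compound 3 (0.60 log units; beyond the scatter), so this ring stands apart from the other two, which lie within the scatter of each other. Nothing available here explains why this ring behaves differently.

The 2-hydroxyphenyl group differs from 3-methoxyphenyl both in its substituent and in where that substituent sits, and it carries a hydrogen-bond donor where 3-methoxyphenyl has none, so these compounds cannot separate those changes. Going by these compounds, whether an amine or a carboxylic acid on this ring would give a similar number also remains open.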